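Carboxy in place of (piperidin-1-yl)methyl: working notes

The compounds below may be only part of what the source reports. "The series", "measured", "known", "first", "only" and "open" are said of these compounds alone.

Measured so far:
- compound 1 `CCNC(=O)c1noc(-c2cc(C(C)C)c(O)cc2O)c1-c1cc(COCC(N)=O)no1`: "not determined" (no result reported)
- compound 2 `CCNC(=O)c1noc(-c2cc(C(C)C)c(O)cc2O)c1-c1cc(CN2CCCCC2)no1`: 62 nM

In a functional assay on A2780 cells (Homo sapiens) for inhibition (on this read-out higher numbers stand for weaker inhibition and lower numbers for stronger inhibition), compound 2 gives 62 nM. Among the compounds with values here, this is the only number, so it cannot yet be ranked against any other compound. It serves only as the reference point for the next compound.

The next compound to be tested is compound 3 `CCNC(=O)c1noc(-c2cc(C(C)C)c(O)cc2O)c1-c1cc(C(=O)O)no1`. The change is carboxy in place of (piperidin-1-yl)methyl on an aromatic carbon. Carboxy replaces (piperidin-1-yl)methyl on an aromatic carbon, next to the ring nitrogen, and the rest of the structure stays the same.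

Within the data shown here, the series offers no measured step to calibrate this change, so the expectation is a judgement with wide margins. A shift toward weaker inhibition in this assay, beyond the usual scatter, is expected. The expected size is a 24-fold higher number from compound 2 to compound 3 (1.38 log units; beyond the scatter). For compound 3 the estimated value is 1500 nM, with an expected range of 200 nM to 10000 nM.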

Compound 3, half-maximal inhibitory concentration: 20000 nM
The estimate for compound 3 lay 13-fold (1.12 log units) below the measured number; measured number outside the range, above it.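

In this assay, this position on the five-membered aromatic ring clearly responds to its substituent: carboxy in place of (piperidin-1-yl)methyl gives a 320-fold higher number from compound 2 to compound 3 (2.51 log units; beyond the scatter), with the rest of the structure unchanged. This first measured step shows that the shared core alone does not hold inhibition at the level of compound 2, and that the group on this aromatic carbon can shift the read-out by a large margin. No measured property is available to account for the step, so this single pair records only its direction and size.

On these data alone, it remains open whether the step follows from losing the piperidine ring or from gaining the carboxylic acid. A dimethylaminomethyl group, a morpholin-4-ylmethyl group or a primary amide at this position would help separate the two, whereas compound 1, at "not determined" (no result reported), offers no comparison.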